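This account rests on a few compounds, and the source may have more. Where it says the series, first, only, none or still open, it means among the compounds named here.

Of the compounds shown here, two sharing one core have been tested in an ADME assay on HepG2 cells (Homo sapiens) for inhibition, read by resazurin assay, with a stated time of 48 h; on this read-out lower numbers stand for an effect already at smaller amounts and higher numbers for an effect only at larger amounts of compound. Compound 1 `O=C(Nc1ccc2sc(-c3ccc(F)c(F)c3)nc2c1)N1CCCC1` gives > 50000 nM, which is a limit of the assay and not a number. Compound 2 `O=C(Nc1ccc2sc(-c3ccc(F)cc3)nc2c1)N1CCCCC1` gives > 50000 nM, and this too is only a limit. Compound 2 therefore has no exact position on the scale, and the only other result beside it is also a limit.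

Compound 3 `O=C(Nc1ccc2sc(-c3ccc(F)cc3)nc2c1)N1CCCC1` has not yet been measured. It arises from compound 2 with pyrrolidin-1-yl in place of piperidin-1-yl on a carbonyl carbon. Compound 1 already carries pyrrolidin-1-yl in that place, and the expectation leans on both tested compounds because of the limit of > 50000 nM in this assay, at which 2 of the 2 values shown sit. The estimated step of a number no higher from compound 2 to compound 3 (the limit leaves the size open) is expected to stay within the usual scatter of this assay, with no direction favoured. Compound 3 is estimated at 50000 nM, with an expected range from 25000 nM to 100000 nM, and the result is expected most likely to be reported as a limit again.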

Compound 3, half-maximal effective concentration: > 50000 nM
Compound 3: no number, only a limit; the forecaster's own chance of this, stated with the estimate: 85%; the middle value lies on the limit itself.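

Compound 1, compound 2 and compound 3 all stand at a limit and not at a number, so the steps from compound 2 to compound 3 and from compound 1 to compound 3 cannot be read. The compounds shown leave open whether pyrrolidin-1-yl in place of piperidin-1-yl, or hydrogen in place of fluoro, changes the read-out at all: the limit of > 50000 nM in this assay, at which 3 of the 3 values shown sit.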